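A few compounds are considered here, and "the series" means these few. Any claim that something is new, unique, unknown or untested is made for them only; others in the source may bear on it.

Compound 1 `CCC(C(=O)N1CCN(c2cccc(OC)c2)CC1)N1C(=O)CCC1=O`: 0%. Compound 2 `CCC(C(=O)N1CCN(c2ccccc2F)CC1)N1C(=O)CCC1=O`: 100%. Compound 3 `CCC(C(=O)N1CCN(c2cccc(Cl)c2)CC1)N1C(=O)CCC1=O`: 50%.

All three numbers come from a functional assay on the whole organism (strain Swiss) with Mus musculus as the target, in the maximal electroshock model, with a stated time of 0.5 h, at a dose of 300 mg/kg by the intraperitoneal route; on this read-out higher numbers stand for a stronger effect at the one dose given and lower numbers for a weaker effect. Compound 3 stands second highest of the three: the step of a number 50 percentage points higher from compound 1 to compound 3 (beyond the scatter) separates it from compound 1, and the step of a number 50 percentage points lower from compound 2 to compound 3 (beyond the scatter) from compound 2.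

Compound 4 `CCC(C(=O)N1CCN(c2ccccc2)CC1)N1C(=O)CCC1=O` differs from compound 3 as follows: hydrogen in place of chloro on an aromatic carbon. Within the data shown here, no measured step removes a group outright. The closest is a number 50 percentage points higher from compound 1 to compound 3 (beyond the scatter), which exchanged one group for another on an aromatic carbon and was large; the step of a number 50 percentage points lower from compound 2 to compound 3 (beyond the scatter), also large, exchanged whole ring patterns. Neither shows hydrogen at that carbon, so the direction of this step is open and a large step either way is possible. Compound 4 is therefore expected to give about 50%, in the range 0% to 100%, an expected step of no change at the digits printed from compound 3 to compound 4 (within the scatter).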

Compound 4, a percentage reported as activity, at one dose (the size of the read-out at that dose, not a potency): 75%
Compound 4: middle estimate off by 25 percentage points, on the low side; measured number inside the range.
By their numbers in this assay, from the lowest: compound 1; then compound 3; then compound 4; then compound 2.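

With the plain phenyl of compound 4 as a reference in this assay, the substituents on this ring no longer read as a single trend. Chloro stands below hydrogen (a number 25 percentage points higher from compound 3 to compound 4 (beyond the scatter)) and methoxy much further below (a number 75 percentage points higher from compound 1 to compound 4 (beyond the scatter)), whereas the fluoro compound stands above it (a number 25 percentage points lower from compound 2 to compound 4 (beyond the scatter)). A substituent on this ring can therefore go with either a higher or a lower number than hydrogen.

No measurement given here accounts for these differences. From the compounds shown here alone, whether an amine or a carboxylic acid on this ring would stand above or below the phenyl stays open.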